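Methoxy to methyl at the ortho position of the benzamide

The source may report more compounds than this note shows. Statements on the series, on what has been measured and on what is new or still open speak of the compounds shown alone.

Notes on a small benzamide series sharing the sulfonamide-bearing core. Compound 1 `O=C(NCc1ccc(CNS(=O)(=O)c2ccccc2)cc1)c1ccc(F)cc1` carries a fluorine on the benzamide ring; in a functional assay on the whole organism for inhibition, with Mus musculus as the target, with stated times of 30 min and 2 h, at a dose of 10 mg/kg by the intraperitoneal route (on this read-out lower numbers stand for less inhibition and higher numbers for more inhibition at the one dose given (going by the name of the read-out)), compound 1 gives 40%. Compound 2 `COc1ccccc1C(=O)NCc1ccc(CNS(=O)(=O)c2ccccc2)cc1` carries a methoxy instead, placed ortho to a large group, and in this assay compound 2 is recorded as "not active" (no number reported) with no number attached. For the measured compounds named here, compound 2 therefore stands without a measured figure, only the report that it did not show inhibition under the same conditions; no step between the two measured compounds can be counted, and what they show is that compound 1 has a moderate figure where compound 2 has none.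

Compound 3 `Cc1ccccc1C(=O)NCc1ccc(CNS(=O)(=O)c2ccccc2)cc1` differs from compound 2 in one place: methyl in place of methoxy on an aromatic carbon. Going by the values given here, with no measured step available for this change, the expectation rests on compound 2 alone, whose report of "not active" (no number reported) gives little room for a large gain; a higher number than the one reported for compound 2 is possible, but a step beyond the scatter is not expected. Compound 3 is estimated at 15% in this assay, with a range of 0% to 40%, and a real chance that it too is reported without a number.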

Compound 3, a percentage reported as inhibition, in the whole organism at one dose (the size of the read-out at that dose, not a potency): "not active" (no number reported)
Compound 3: no number reported; there is nothing to compare the estimate with.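

In this assay compound 2 gives "not active" (no number reported) and compound 3 gives "not active" (no number reported) so no step can be read between them. Nothing shown here bears on why this result arises.

The compounds shown leave open whether any other group at this place on the aromatic ring gives a number in this read-out.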